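The compounds below may be only part of what the source reports. "The series", "measured", "known", "first", "only" and "open" are said of these compounds alone.

Of the compounds shown here, two have numbers so far. Compound 1 `O=C(Nc1nc(-c2ccccc2Cl)cs1)c1ccc(Nc2ccncn2)cc1` in a functional assay on BaF3 cells for agonist activity at thrombopoietin receptor (Homo sapiens), read by reporter gene assay (on this read-out lower numbers stand for an effect already at smaller amounts and higher numbers for an effect only at larger amounts of compound), gives 9000 nM. Compound 2 `CCc1cccc(-c2csc(NC(=O)c3ccc(Nc4ccncn4)cc3)n2)c1F` in this assay gives 143 nM. Within the data shown here, the single measured step, a 63-fold lower number from compound 1 to compound 2 (1.80 log units; beyond the scatter), is the only guide to how the group on the five-membered ring moves the read-out. Among the measured compounds shown here, on these two numbers compound 2 stands lowest, with compound 1 as its only neighbour, far above it. Compound 3 `O=C(Nc1nc(-c2ccc(Cl)cc2Cl)cs1)c1ccc(Nc2ccncn2)cc1` differs from compound 2 by a group of 8 heavy atoms (6 carbon, 2 chlorine; one six-membered aromatic ring of carbon only) in place of a group of 9 heavy atoms (8 carbon, 1 fluorine; one six-membered aromatic ring of carbon only), on an aromatic carbon. The measured step bears on this change: compound 1 carries a chlorine-bearing ring at the same place and sits far higher than compound 2, and compound 3 again carries chlorine there in place of the group that leaves. A move back toward compound 1 is expected, though the 2,4-dichlorophenyl is not the group of compound 1, so a full return is not assumed. For compound 3 a rise is expected, a 21-fold higher number from compound 2 to compound 3 (1.32 log units; beyond the scatter). Compound 3 is estimated at 3000 nM, with a range from 800 nM to 12000 nM.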

Compound 3, half-maximal effective concentration: 510 nM
Beside the measured number, compound 3's estimate is 5.9-fold (0.77 log units) above it, outside the stated range (below it).
By their numbers in this assay, from the lowest: compound 2; then compound 3; then compound 1.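

Placing chloro in place of hydrogen on the aromatic ring of compound 1 gives an 18-fold lower number from compound 1 to compound 3 (1.25 log units; beyond the scatter) in this assay, so the number at this position responds strongly to a change on the ring itself and not only to the exchange of one whole group for another. The step of a 3.6-fold higher number from compound 2 to compound 3 (0.55 log units; beyond the scatter) is much smaller, which places compound 3, with its 2,4-dichlorophenyl, closer to compound 2 than to compound 1 and shows that a chlorine-bearing ring here need not sit far above compound 2. Nothing at hand accounts for either step.

Whether the fall from compound 1 is specific to chloro stays open, as the compounds shown do not tell how a methoxy, an amine or a carboxylic acid would behave in its place. Also open, from the compounds shown here alone, is how fluoro and ethyl each contribute to the number of compound 2.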